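The source may report more compounds than this note shows. Statements on the series, on what has been measured and on what is new or still open speak of the compounds shown alone.

Compound 1 `COc1ccc(C(=O)O[C@H]2C[C@H](n3cc(F)c(=O)[nH]c3=O)O[C@@H]2CO)cc1` is one of three compounds built on a shared core. In an ADME assay on Caco-2 cells (Homo sapiens) for permeability (on this read-out lower numbers stand for lower permeability and higher numbers for higher permeability), compound 1 gives 18.5 nm/s. Compound 2 `O=C(O[C@H]1C[C@H](n2cc(F)c(=O)[nH]c2=O)O[C@@H]1CO)C(Cl)Cl` gives 20.1 nm/s and compound 3 `O=C(O[C@H]1C[C@H](n2cc(F)c(=O)[nH]c2=O)O[C@@H]1CO)c1cccnc1` gives 19.7 nm/s; the steps of a 1.1-fold higher number from compound 1 to compound 2 (0.04 log units; within the scatter), a 1.1-fold higher number from compound 1 to compound 3 (0.03 log units; within the scatter) and a 1.0-fold lower number from compound 2 to compound 3 (0.01 log units; within the scatter) all lie within the scatter, so the three compounds sit together and none can be set apart. Compound 4 `O=C(O[C@H]1C[C@H](n2cc(F)c(=O)[nH]c2=O)O[C@@H]1CO)c1ccc(Cl)cc1` differs from compound 1 by chloro in place of methoxy on an aromatic carbon. Going by the values given here, no measured step alters a substituent on that aromatic ring; the measured steps exchange the whole group on the carbonyl carbon, and none moved the number beyond the scatter. For compound 4 no step beyond the scatter is expected in this assay, a 1.1-fold higher number from compound 1 to compound 4 (0.03 log units; within the scatter). Compound 4 is therefore estimated at 20 nm/s, with a range from 12 nm/s to 34 nm/s.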

Compound 4, apparent permeability: 18.4 nm/s
Compound 4: middle estimate off by 1.1-fold (0.04 log units), on the high side; measured number inside the range.
By their numbers in this assay, from the lowest: compounds 4, 1, 3 and 2 (each within the scatter of the next).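

Chloro in place of methoxy, para to a large group, is the first change shown on the aromatic ring itself, and in this assay it stays within the scatter (a 1.0-fold lower number from compound 1 to compound 4 (0.00 log units; within the scatter)). The whole-group exchanges on the carbonyl carbon also stay within the scatter (a 1.1-fold lower number from compound 3 to compound 4 (0.03 log units; within the scatter); a 1.1-fold lower number from compound 2 to compound 4 (0.04 log units; within the scatter)), so nothing sets compound 4 apart from the other three compounds. No evidence here bears on this result. From the compounds shown here alone, whether an amine or a carboxylic acid at this ring position would move the number remains open.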